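The source may hold more compounds than are shown below. What is called first, only, known or untested is meant among the compounds shown, and "the series" means these compounds.

Working notes on the series. One group varies on the shared core, on a saturated chain carbon bound to an aromatic carbon and an oxygen on a saturated carbon. In a functional assay on PC-3 cells (Homo sapiens) for inhibition, read by MTT assay, with a stated time of 48 h, tested at 10 uM (a lower number here means less inhibition of growth, a higher number more inhibition of growth at the concentration tested), compound 1 (`Cc1oc2c([C@H]3CCN(C)C[C@H]3O)c(O)cc(O)c2c(=O)c1C(O)c1ccc(Cl)cc1`), with 4-chlorophenyl, gives 41%. Compound 2 (`Cc1oc2c([C@H]3CCN(C)C[C@H]3O)c(O)cc(O)c2c(=O)c1C(O)c1c(F)cccc1Cl`), with 2-chloro-6-fluorophenyl, gives 0%, and compound 3 (`Cc1oc2c([C@H]3CCN(C)C[C@H]3O)c(O)cc(O)c2c(=O)c1C(O)c1csc([N+](=O)[O-])c1`), with 5-nitrothiophen-3-yl, gives 0%. Compound 3 is thus level with compound 2, the two together lowest of the three numbers.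

Compound 4 (`COc1ccc(C(O)c2c(C)oc3c([C@H]4CCN(C)C[C@H]4O)c(O)cc(O)c3c2=O)cc1Br`) changes the same place: 3-bromo-4-methoxyphenyl in place of 5-nitrothiophen-3-yl on a saturated chain carbon bound to an aromatic carbon and an oxygen on a saturated carbon. Going by the values given here, two measured steps bear on this, a number 41 percentage points lower from compound 1 to compound 3 (beyond the scatter) and a number 41 percentage points lower from compound 1 to compound 2 (beyond the scatter), both large and beyond the scatter. A third, no change at the digits printed from compound 2 to compound 3 (within the scatter), lies within the scatter. The read-out therefore can move widely with this group, but a six-membered aromatic ring of carbon only does not settle the outcome: compound 1 has such a ring and shows inhibition, while compound 2 also has one and gives 0%. Among the compounds with values here, no measured compound carries bromo or methoxy substitution, so the size remains poorly fixed. A moderate upward move in this assay is expected, with no change beyond the scatter still possible, and the expected step is a number 22 percentage points higher from compound 3 to compound 4 (beyond the scatter). For compound 4 the estimated value is 22%, with an expected range of 0% to 48%.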

Compound 4, percent growth inhibition at one concentration: 0%
Beside the measured number, compound 4's estimate is 22 percentage points above it; the measured number falls inside the stated range.
By their numbers in this assay, from the lowest: compounds 2, 3 and 4 (each within the scatter of the next); then compound 1.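

In this assay, the steps of no change at the digits printed from compound 3 to compound 4 (within the scatter) and no change at the digits printed from compound 2 to compound 4 (within the scatter) place 3-bromo-4-methoxyphenyl level with both 5-nitrothiophen-3-yl and 2-chloro-6-fluorophenyl, so a third group at this position fails to lift the read-out, and the larger group, with its six-membered aromatic ring of carbon only, gains nothing over the five-membered aromatic ring with a hetero atom. Going by these compounds alone, the step of a number 41 percentage points lower from compound 1 to compound 4 (beyond the scatter) leaves 4-chlorophenyl as the only group of the four separated from the rest beyond the scatter, and since compounds 1, 2 and 4 all carry a halogen on a six-membered aromatic ring of carbon only, neither that ring nor a halogen on it is enough, with compounds 2 and 4 going against any such reading. The data at hand offer no measurement that explains this difference.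

Going by these compounds, it remains open whether 4-chlorophenyl is a rare exception at this position or whether close relatives such as 4-bromophenyl, 4-methoxyphenyl or unsubstituted phenyl would also show inhibition. Equally open, on these data alone, is how an amine on the ring, as in 4-aminophenyl, would read in this assay.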